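The compounds below may be only part of what the source reports. "The series", "measured", "known", "first", "only" and "open" are said of these compounds alone.

Measured compounds, with values in a functional assay on A549 cells (Homo sapiens) for antiproliferative activity, read by MTT assay; on this read-out lower numbers stand for stronger inhibition and higher numbers for weaker inhibition:
compound 1 `N#Cc1ncn(Cc2ccccc2Cl)c1/N=C/c1c[nH]c2ccccc12` gives 10900 nM
compound 2 `N#Cc1ncn(Cc2ccccc2Cl)c1/N=C/c1ccc(O)cc1` gives 35100 nM

Compound 2 stands at the highest of the two numbers; its nearest neighbour, compound 1, lies at a lower number, and that gap is beyond the usual scatter. For the measured compounds named here, no step between the two measured compounds can be cut out as a single change, so the two values only show that the indole-bearing compound 1 inhibits more strongly than compound 2.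

Compound 3 `N#Cc1ncn(Cc2ccccc2Cl)c1/N=C/c1ccc(Cl)cc1` differs from compound 2 by chloro in place of hydroxy on an aromatic carbon. Going by the values given here, no measured pair carries this change, so its size in this assay is unknown. The expectation is a modest step toward a lower number, possibly no further than the scatter allows.

For compound 3 the estimate is 20000 nM with a range of 6000 nM to 60000 nM. The expected step is a 1.8-fold lower number from compound 2 to compound 3 (0.24 log units; within the scatter).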

Compound 3, half-maximal inhibitory concentration: 30800 nM
Beside the measured number, compound 3's estimate is 1.5-fold (0.19 log units) below it; measured number inside the range.
By their numbers in this assay, from the lowest: compound 1; then compounds 3 and 2 (each within the scatter of the next).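

In this assay, for the compounds shown here, the change from 4-hydroxyphenyl to 4-chlorophenyl gives a 1.1-fold lower number from compound 2 to compound 3 (0.06 log units; within the scatter) and is the only single-change step available. At this position, on an aromatic carbon para to a large group, the read-out does not separate chloro from hydroxy. The hydrogen-bond donor and acceptor counted for hydroxy can thus leave without a change beyond the scatter, at least for this one pair.

Still open, as far as these compounds go, is whether an amine, a methoxy group or a carboxylic acid at the same position would read apart from these two compounds, since a single pair fixes no trend for the position. No supporting measurement on hand bears on why chloro and hydroxy read alike here.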